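The compounds below may be only part of what the source reports. "The series", "measured", "known", "first", "only" and "open" are said of these compounds alone.

Among the compounds with values here, in a functional assay on MDA-MB-231 cells (Homo sapiens) for antiproliferative activity, read by MTT assay, with a stated time of 72 h (on this read-out lower numbers stand for stronger inhibition and higher numbers for weaker inhibition), compound 1 `O=C(CCc1cccc2c1B(O)OC2)Nc1ccccc1` gives 230 nM and has the lowest number of the compounds measured so far. Compound 3 `O=C(CCc1cccc2c1B(O)OC2)Nc1ccc([N+](=O)[O-])cc1` comes nearest at 36000 nM on that scale. Compound 2 `CCOC(=O)c1ccc(NC(=O)CCc2cccc3c2B(O)OC3)cc1` stands at > 100000 nM as a limit of the assay and not a number.

The unmeasured compound 4 `O=C(CCc1cccc2c1B(O)OC2)Nc1cccc(-c2ccccc2)c1` differs from compound 1 by phenyl in place of hydrogen on an aromatic carbon, meta to a large group, with phenyl in place of hydrogen on an aromatic carbon as the count of that change. Within the data shown here, two measured steps bear on it, as each also replaces hydrogen on an aromatic carbon. Ethoxycarbonyl gave an at least 430-fold higher number from compound 1 to compound 2 (2.63 log units; beyond the scatter) for that replacement. Nitro gave a 160-fold higher number from compound 1 to compound 3 (2.19 log units; beyond the scatter) in the same direction. Both steps are large, whereas an at least 2.7-fold lower number from compound 2 to compound 3 (0.44 log units; beyond the scatter) separates the two substituted compounds from each other. Neither group is phenyl, so only the direction carries over.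

Going by compound 3 at 36000 nM a higher number is expected for compound 4 in this assay but probably a smaller rise than those two steps. The expected change is a 13-fold higher number from compound 1 to compound 4 (1.12 log units; beyond the scatter) in size. Compound 4 is thus estimated at 3000 nM with 200 nM to 40000 nM as the expected range.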

Compound 4, half-maximal inhibitory concentration: 220 nM
For compound 4 the middle estimate is 14-fold (1.13 log units) above the measured one, and the stated range covers the measured number.
By their numbers in this assay, from the lowest: compounds 4 and 1 (each within the scatter of the next); then compound 3. At a limit, above all of these: compound 2.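

In this assay, phenyl in place of hydrogen on an aromatic carbon, meta to a large group, gives a 1.0-fold lower number from compound 1 to compound 4 (0.02 log units; within the scatter), so this change leaves the number within the scatter of compound 1. Adding a group to this aromatic ring therefore does not by itself bring a large rise, even though the two earlier replacements did, with an at least 430-fold higher number from compound 1 to compound 2 (2.63 log units; beyond the scatter) and a 160-fold higher number from compound 1 to compound 3 (2.19 log units; beyond the scatter). The value of compound 2 is a limit and not a number, so its step gives only a minimum size: the limit of > 100000 nM in this assay, at which 1 of the 4 values shown sits.

The compounds shown do not separate the effect of the group from that of its place, as phenyl sits on a different aromatic carbon from ethoxycarbonyl and nitro. They also leave open whether the number would stay level with a methyl, an amine or a carboxylic acid meta to a large group, or with phenyl moved to the aromatic carbon that carries nitro in compound 3.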